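Ethylcarbamoyl in place of oxetan-3-yl: clearance working notes

A few compounds are considered here, and "the series" means these few. Any claim that something is new, unique, unknown or untested is made for them only; others in the source may bear on it.

Measured in an in vitro ADME assay on microsomes from liver (Homo sapiens) for pharmacokinetics, read by LC-MS, with a stated time of 10 min, tested at 1 uM; on this read-out lower numbers stand for slow clearance and higher numbers for fast clearance
compound 1 `CN1C[C@H](C(=O)Nc2ccc(F)cc2)[C@@H](c2ccc(/C=C/C(=O)Nc3ccccc3N)cc2)C1` gives 5 mL/min/kg
compound 2 `Nc1ccccc1NC(=O)/C=C/c1ccc([C@H]2CN(C3COC3)C[C@@H]2C(=O)Nc2ccc(Cl)cc2)cc1` gives 13 mL/min/kg

Of the two measured compounds, compound 2 has the higher number, and its gap to compound 1 lies beyond the usual scatter. The next compound to be measured is compound 3 `CCNC(=O)N1C[C@H](C(=O)Nc2ccc(Cl)cc2)[C@@H](c2ccc(/C=C/C(=O)Nc3ccccc3N)cc2)C1`, which differs from compound 2 by ethylcarbamoyl in place of oxetan-3-yl on an amine nitrogen in a ring. Among the measured compounds shown here, the series holds no measured step between compounds that differ in one place, so nothing measured speaks directly to this change. In this assay no step beyond the scatter is expected, with only a slight lean towards a lower number. The estimate amounts to a 1.3-fold lower number from compound 2 to compound 3 (0.11 log units; within the scatter) and remains tentative. Compound 3 is expected at 10 mL/min/kg (4 mL/min/kg to 25 mL/min/kg).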

Compound 3, clearance: 9 mL/min/kg
Beside the measured number, compound 3's estimate is 1.1-fold (0.05 log units) above it, and the stated range covers the measured number.
By their numbers in this assay, from the lowest: compounds 1, 3 and 2 (each within the scatter of the next, the first and the last beyond it).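

In this assay, this position on the amine nitrogen in a ring now has its first measured step: a 1.4-fold lower number from compound 2 to compound 3 (0.16 log units; within the scatter). The step removes the four-membered non-aromatic ring and brings in a hydrogen-bond donor, yet compound 2 and compound 3 remain within the scatter of each other, so neither group separates from the other on clearance at this position. Nothing measured explains this result.

Still open, from the compounds shown here alone, is how clearance responds to other groups on this nitrogen, such as a methylsulfonyl group or a longer chain in place of the ethyl in ethylcarbamoyl. A single step also leaves open whether the same exchange would give a similar result with a group other than (4-chlorophenyl)carbamoyl on the ring.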